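The source may hold more compounds than are shown below. What is called first, only, known or untested is meant among the compounds shown, and "the series" means these compounds.

In a functional assay on OVCAR-3 cells (Homo sapiens) for cytotoxicity, read by sulforhodamine B assay (on this read-out higher numbers stand for weaker inhibition of growth and lower numbers for stronger inhibition of growth), the compounds measured so far give these numbers:

- compound 1 `CC1=CC[C@@H]([C@@](C)(O)CCCC(C)(C)NC=S)CC1` gives 93700 nM
- compound 2 `CC1=CC[C@@H]([C@@](C)(O)CCCC(C)(C)NC(=S)N/N=C\c2ccccc2)CC1` gives 12900 nM
- compound 3 `CC1=CC[C@@H]([C@@](C)(O)CCCC(C)(C)NC(=S)N/N=C\c2ccc(O)cc2)CC1` gives 17400 nM

Compound 3 holds the middle of these three numbers. It lies within the scatter of compound 2 and clearly under compound 1.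

Compound 4 `CC1=CC[C@@H]([C@@](C)(O)CCCC(C)(C)NC(=S)N/N=C\c2ccccc2Cl)CC1` differs from compound 3 as follows: 2-chlorophenyl in place of 4-hydroxyphenyl on a carbon with a double bond to nitrogen. In words, 2-chlorophenyl stands in place of 4-hydroxyphenyl on a carbon with a double bond to nitrogen.

Going by the values given here, two measured steps bear on this change. The larger, a 7.3-fold lower number from compound 1 to compound 2 (0.86 log units; beyond the scatter), brought in the aromatic ring that compound 4 keeps. Among the compounds with values here, the closer guide is a 1.3-fold higher number from compound 2 to compound 3 (0.13 log units; within the scatter), the only measured change on that ring, and it stays within the scatter. Within the data shown here, no measured compound carries chlorine, so this guide is thin. Even so, no step beyond the scatter is expected in this assay.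

The expected change is a 1.2-fold lower number from compound 3 to compound 4 (0.09 log units; within the scatter). For compound 4 the estimated value is 14000 nM, with an expected range from 7000 nM to 28000 nM.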

Compound 4, concentration for total growth inhibition: > 100000 nM
Compound 4 gave a limit, no number; the forecaster's own chance of this, stated with the estimate: 3%; at least 7.1-fold (0.85 log units) between middle value and limit.
By their numbers in this assay, from the lowest: compounds 2 and 3 (each within the scatter of the next); then compound 1. At a limit, above all of these: compound 4.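

In this assay, substitution on the aromatic ring is not always silent: hydroxy in place of hydrogen stayed within the scatter, whereas chloro in place of hydrogen gives an at least 7.7-fold higher number from compound 2 to compound 4 (0.88 log units; beyond the scatter). Likewise, 2-chlorophenyl in place of 4-hydroxyphenyl on the carbon with a double bond to nitrogen gives an at least 5.7-fold higher number from compound 3 to compound 4 (0.75 log units; beyond the scatter), so these two groups are not interchangeable at this place. Compound 4 stands at a limit, not at a number: the limit of > 100000 nM in this assay, at which 1 of the 4 values shown sits.

The step from compound 3 changes both the group on the ring and where it sits, and the compounds shown do not separate these two changes. From the compounds shown here alone, whether a methoxy group or an amine in place of that chloro would keep the growth inhibition seen with compound 2 also stays open.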